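A few compounds are considered here, and "the series" means these few. Any claim that something is new, unique, unknown or untested is made for them only; others in the source may bear on it.

In a functional assay on the whole organism (brain) with Mus musculus as the target (on this read-out higher numbers stand for an effect only at larger amounts of compound and lower numbers for an effect already at smaller amounts), compound 3 (`CCc1ccc(OCCc2c[nH]cn2)cc1`) gives > 10 mg/kg, which is a limit and not a number. Compound 1 (`FC(F)(F)c1ccc(OCCc2c[nH]cn2)cc1`) gives > 10 mg/kg, also a limit. Only compound 2 (`Cc1ccc(OCCc2c[nH]cn2)cc1`) has a number, 2.3 mg/kg, reached by an at least 4.3-fold lower number from compound 1 to compound 2 (0.63 log units; beyond the scatter). Compound 4 (`CCCc1ccc(OCCc2c[nH]cn2)cc1`) follows from compound 3 by methyl in place of hydrogen on a saturated chain carbon, two bonds along the chain from an aromatic carbon, turning ethyl to propyl. Among the compounds with values here, the closest precedent is the same kind of change one bond further in, which gave an at least 4.3-fold higher number from compound 2 to compound 3 (0.63 log units; beyond the scatter). Since compound 3 offers only a limit, the size of the next step cannot be fixed, though no return towards the value of compound 2 is expected. The expected outcome is a number no higher from compound 3 to compound 4 (the limit leaves the size open). Compound 4 is estimated at 10 mg/kg, within an expected range of 3 mg/kg to 30 mg/kg.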

Compound 4, dose for half-maximal effect: 1.6 mg/kg
Beside the measured number, compound 4's estimate is 6.3-fold (0.80 log units) above it, outside the stated range (below it).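

In this assay, adding to the chain does not push the read-out in one direction: there is an at least 6.2-fold lower number from compound 3 to compound 4 (0.79 log units; beyond the scatter), the opposite sign to the same kind of change one bond further in. Propyl thus stands level with methyl, with a 1.4-fold lower number from compound 2 to compound 4 (0.16 log units; within the scatter), which leaves ethyl out of line among these three chains. Propyl also differs clearly from trifluoromethyl, with an at least 6.2-fold lower number from compound 1 to compound 4 (0.79 log units; beyond the scatter).

The full size of the steps from compound 1 and compound 3 stays open, since each of these compounds has only a limit: the limit of > 10 mg/kg in this assay, at which 2 of the 4 values shown sit. Whether a longer chain such as butyl, or a branched isopropyl, would match compound 4 also stays open.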